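This account rests on a few compounds, and the source may have more. Where it says the series, first, only, none or still open, it means among the compounds named here.

The two measured compounds share one core, and the account begins with the weaker of them. Compound 1 `Cc1c(Cl)cccc1CCCCOc1ccc(C#Cc2cccc3c(CC(=O)O)c(C)n(CCCCC(=O)O)c23)cc1` gives 65 nM in a functional assay on CHO-K1 cells for antagonist activity at cysteinyl leukotriene receptor 1 (Homo sapiens), read by fluorescence and calcium flux, with stated times of 30 min and 1 h (a lower number here means a stronger inhibitor, a higher number a weaker inhibitor), the higher of the two numbers obtained so far. Compound 2 `Cc1c(Cl)cccc1CCCCOc1ccc(C#Cc2cccc3c(CCC(=O)O)c(C)n(CCCCC(=O)O)c23)cc1` gives 25 nM in this assay. Within the data shown here, the single measured step, a 2.6-fold lower number from compound 1 to compound 2 (0.41 log units; beyond the scatter), lengthens the acid chain on the saturated carbon bound to an aromatic carbon. Compound 3 `Cc1c(Cl)cccc1CCCCOc1ccc(C#Cc2cccc3c(CC(=O)O)c(C)n(CCCC(=O)O)c23)cc1` differs from compound 1 in another place: carboxy in place of carboxymethyl on a saturated chain carbon, three bonds along the chain from an aromatic nitrogen. Among the measured compounds shown here, no measured step touches that chain, so the step from compound 1 to compound 2 bears on it only by analogy, as a sign that moving an acid by one carbon shifts the number modestly. A modest step is therefore expected, a 1.4-fold higher number from compound 1 to compound 3 (0.14 log units; within the scatter), without a firm direction. Compound 3 is expected to give about 90 nM in this assay, between 35 nM and 230 nM.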

Compound 3, half-maximal inhibitory concentration in the cysteinyl leukotriene receptor 1 assay: 5.5 nM
Beside the measured number, compound 3's estimate is 16-fold (1.21 log units) above it; the whole stated range lies above it.
By their numbers in the cysteinyl leukotriene receptor 1 assay, from the lowest: compound 3; then compound 2; then compound 1.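

On the chain at the aromatic nitrogen, the change from 4-carboxybutyl to 3-carboxypropyl gives in the cysteinyl leukotriene receptor 1 assay a 12-fold lower number from compound 1 to compound 3 (1.07 log units; beyond the scatter). This is a much larger step than the one on the other acid chain, a 2.6-fold lower number from compound 1 to compound 2 (0.41 log units; beyond the scatter), so this position is the more sensitive of the two places changed so far, and here it is the shorter acid chain that gives the lower number. The same change also gives the higher number in a physicochemical assay for permeability, using PAMPA, with a stated time of 4 h, at pH 7.4, tested at 50 uM (a lower number here means that the compound crosses the layer more slowly, a higher number that the compound crosses the layer faster), where compound 1 gives 1 10^-6 cm/s and compound 3 gives 4.4 10^-6 cm/s, so on this pair the gain at the receptor comes with faster passage, not slower: the measured apparent permeability of compound 1, 1 10^-6 cm/s, and of compound 3, 4.4 10^-6 cm/s, a 4.4-fold higher number (0.64 log units; beyond the scatter)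

The compounds shown leave open whether 2-carboxyethyl at this place would lower the number further, or whether the trend reverses. They also leave open whether a tetrazole or an amide could stand in for the carboxylic acid on this chain, and whether the two favourable acid chain changes add up in one compound.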